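The source may hold more compounds than are shown below. What is called first, only, known or untested is meant among the compounds shown, and "the series" means these compounds.

In a functional assay on brain (Rattus norvegicus, strain Wistar) for inhibition (a higher number here means a weaker inhibitor, a lower number a stronger inhibitor), compound 1 `CCCCCc1ccc(-c2c(C)[nH]c(=O)n2C)cc1` gives 5900 nM and compound 2 `Cc1[nH]c(=O)n(C)c1-c1ccc(Oc2ccccc2)cc1` gives 8100 nM. These two numbers lie within the usual scatter of each other, so compound 1 cannot be ranked apart from compound 2. Compound 3 `CCCCCc1ccc(-c2c(C)[nH]c(=O)n2C2CCCCC2)cc1` keeps the core of compound 1 and changes one group: cyclohexyl in place of methyl on an aromatic nitrogen. Within the data shown here, the only measured step, a 1.4-fold higher number from compound 1 to compound 2 (0.14 log units; within the scatter), is phenoxy in place of pentyl on an aromatic carbon. That step lies within the scatter, but it concerns a different place on the molecule, so it says little about this nitrogen. Among the measured compounds shown here, no measured pair shows a change there, so no direction can be expected with confidence, and the working expectation is no step beyond the scatter in this assay, with wide uncertainty. The step expected is a 1.2-fold lower number from compound 1 to compound 3 (0.07 log units; within the scatter). For compound 3 the estimated value is 5000 nM, with an expected range from 1000 nM to 25000 nM.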

Compound 3, half-maximal inhibitory concentration: 10600 nM
Compound 3: the middle estimate sits 2.1-fold (0.33 log units) below what was measured, and the stated range covers the measured number.
By their numbers in this assay, from the lowest: compounds 1, 2 and 3 (each within the scatter of the next).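

Putting cyclohexyl in place of methyl on this aromatic nitrogen gives a 1.8-fold higher number from compound 1 to compound 3 (0.25 log units; within the scatter) in this assay for a swap from a single carbon to a six-membered non-aromatic ring of carbon only. Among these compounds, this nitrogen therefore takes a far larger group, with no hydrogen-bond donors or acceptors added, without a step beyond the scatter, so the size of the group here has not yet been seen to matter in this assay. Nothing available explains why the number stays within the scatter.

Still open, on these data alone, is whether a group of another kind on this nitrogen, such as an amine-bearing chain or a phenyl ring, would move the number beyond the scatter. As far as these compounds go, it is equally open whether cyclohexyl on this nitrogen would behave the same way with phenoxy in place of pentyl.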